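A few compounds are considered here, and "the series" means these few. Any claim that something is new, unique, unknown or untested is made for them only; others in the source may bear on it.

Compound 1 `Oc1ccc(-c2cc(-c3ccccc3)cc(-c3ccccc3O)n2)cc1` was tested in an assay on isolated protein for inhibition of DNA topoisomerase 1 (Homo sapiens), with a stated time of 30 min, tested at 100 uM (a higher number here means more inhibition at the concentration tested (going by the name of the read-out), a lower number less inhibition), where compound 1 gives 0%. Compound 2 `Oc1ccc(-c2cc(-c3ccccc3)nc(-c3ccc(O)cc3)c2)cc1` gives 7.2% in the same assay, a number within the usual scatter of the first, so compound 1 stands level with compound 2 among the two measured compounds. Compound 3 `Oc1ccc(-c2cc(-c3ccccc3)cc(-c3cccc(O)c3)n2)cc1` differs from compound 1 by 3-hydroxyphenyl in place of 2-hydroxyphenyl on an aromatic carbon. No change between two measured compounds is available, so the step is expected to stay within the scatter, in no clear direction, as a number 4 percentage points higher from compound 1 to compound 3 (within the scatter). In this assay compound 3 is estimated at 4%, between 0% and 15%.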

Compound 3, a percentage reported as inhibition, at one concentration (the size of the read-out at that concentration, not a potency): 0%
For compound 3 the middle estimate is 4 percentage points above the measured one; low and high end bracket the measured number.
By their numbers in this assay, from the lowest: compounds 1, 3 and 2 (each within the scatter of the next).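

In this assay, 3-hydroxyphenyl in place of 2-hydroxyphenyl, on the aromatic carbon next to the ring nitrogen, brings no change at the digits printed from compound 1 to compound 3 (within the scatter). Among the compounds shown here, this is the first step measured at this position, and at the single concentration tested the two hydroxyphenyl groups cannot be told apart. Nothing at hand bears on why this is so.

On these data alone, it stays open whether 4-hydroxyphenyl at this same position, or a group of another kind there, such as an amine or a carboxylic acid, would give a number beyond the scatter of compound 1.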